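Removing the Phenyl from an Inactive Alkyne

This account rests on a few compounds, and the source may have more. Where it says the series, first, only, none or still open, it means among the compounds named here.

Compound 1 `C=Cc1nc2ccccc2[se]1` gives > 40000 nM in a functional assay on HCT-116 cells (Homo sapiens) for cytotoxicity, with a stated time of 3 days (a higher number here means a weaker inhibitor, a lower number a stronger inhibitor), which is a limit of the assay and not a number. Compound 3 `C=Cc1nc2ccccc2o1` gives > 40000 nM in this assay, again a limit. Compound 2 `C#CCNC(=O)c1csc(C#Cc2ccccc2)n1` gives > 40000 nM, also only a limit. Compound 2 therefore stands at the limit of > 40000 nM in this assay, at which 3 of the 3 values shown sit.

Compound 4 `C#CCNC(=O)c1csc(C#C)n1` carries hydrogen in place of phenyl on a triple-bonded carbon. Within the data shown here, no measured pair shows what such a change does in this assay, so only a small step, perhaps none beyond the scatter, is expected toward a stronger value. The expected change is an at least 1.1-fold lower number from compound 2 to compound 4 (0.05 log units; that floor lies within the scatter). The estimate for compound 4 is 35000 nM, with an expected range from 12000 nM to 70000 nM.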

Compound 4, half-maximal inhibitory concentration: 19200 nM
Beside the measured number, compound 4's estimate is 1.8-fold (0.26 log units) above it, and the stated range covers the measured number.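

Hydrogen in place of phenyl on a triple-bonded carbon gives the first step that can be read in this assay, and it runs toward a stronger value: an at least 2.0-fold lower number from compound 2 to compound 4 (0.31 log units; beyond the scatter). The size of this step is only a floor, since the value for compound 2 is a limit. Compound 4 is the only compound shown that gets off that limit: the limit of > 40000 nM in this assay, at which 3 of the 4 values shown sit.

The compounds shown leave open whether a small group on this carbon, such as a methyl or an aminomethyl chain, would do better or worse than hydrogen.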